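Chloro in Place of Acetoxy: Expected Whole-Animal Inhibition

The source may report more compounds than this note shows. Statements on the series, on what has been measured and on what is new or still open speak of the compounds shown alone.

Compound 3 `CC(=O)CCc1ccc2cc(OC(C)=O)ccc2c1` gives 2% in a functional assay on the whole organism (strain Wistar) for inhibition, with Rattus norvegicus as the target, with a stated time of 5 days, at a dose of 50 mg/kg by the oral route (a higher number here means more inhibition at the dose given (going by the name of the read-out), a lower number less inhibition), the lowest of the three numbers measured. Compound 1 `CCC(=O)CCc1ccc2cc(OC)ccc2c1` gives 7%, a number within the scatter of compound 3, while compound 2 `COc1ccc2cc(CCC(C)O)ccc2c1` gives 32%, a number beyond the scatter above it. Compound 4 `CC(=O)CCc1ccc2cc(Cl)ccc2c1` differs from compound 3 by chloro in place of acetoxy on an aromatic carbon. Within the data shown here, the only measured step, a number 25 percentage points higher from compound 1 to compound 2 (beyond the scatter), concerns a change on the saturated chain and not on the aromatic carbon, so nothing measured here speaks directly to this change. Among the measured compounds shown here, with no guide for the step, no change beyond the scatter is expected, and the estimated step is a number 6 percentage points higher from compound 3 to compound 4 (within the scatter). Compound 4 is therefore expected to give 8%, within the range 0% to 25%.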

Compound 4, a percentage reported as inhibition, in the whole organism at one dose (the size of the read-out at that dose, not a potency): 53%
Estimate against measurement, compound 4: 45 percentage points below; the measured number lies above the stated range.
By their numbers in this assay, from the lowest: compounds 3 and 1 (each within the scatter of the next); then compound 2; then compound 4.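

Chloro in place of acetoxy on this aromatic carbon gives a number 51 percentage points higher from compound 3 to compound 4 (beyond the scatter) in this assay, so the group at this position can strongly change the read-out, whereas the one earlier step lay on the saturated chain. The change swaps four heavy atoms and two hydrogen-bond acceptors for one heavy atom and no acceptor, and this single step cannot separate those differences. No measured explanation for the rise is available. Going by these compounds, whether other groups here, such as bromo or an amine, would give a similar number remains open. So does whether chloro would have the same effect with a different chain on the core.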